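From ethoxycarbonyl to methoxycarbonyl on compound 1

The source may hold more compounds than are shown below. What is called first, only, known or untested is meant among the compounds shown, and "the series" means these compounds.

Measured so far in a toxicity assay on HEK293 cells (Homo sapiens) for cytotoxicity; a higher number here means a weaker inhibitor, a lower number a stronger inhibitor:

compound 1 `CCOC(=O)c1ccc(N2NC(=O)/C(=C/c3ccco3)C2=O)cc1` gives > 100000 nM
compound 2 `CCOC(=O)c1ccc(N2NC(=O)/C(=C/c3ccccc3O)C2=O)cc1` gives > 100000 nM
compound 3 `CCOC(=O)c1ccc(N2NC(=O)/C(=C\c3ccccc3)C2=O)cc1` gives > 100000 nM

Each of these entries is a limit of the assay and not a number. Compound 1 therefore has no exact position, and its entry of > 100000 nM is only a limit. The whole set comes down to the limit of > 100000 nM in this assay, at which 3 of the 3 values shown sit.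

Compound 4 `COC(=O)c1ccc(N2NC(=O)/C(=C/c3ccco3)C2=O)cc1` differs from compound 1 in its ester, where ethoxycarbonyl becomes methoxycarbonyl: hydrogen in place of methyl on a saturated chain carbon bound to an oxygen next to a carbonyl group. In words, this is hydrogen in place of methyl on a saturated chain carbon bound to an oxygen next to a carbonyl group.

Among the measured compounds shown here, the only measured step is a step that the two limits leave unreadable from compound 1 to compound 2, with 2-hydroxyphenyl in place of furan-2-yl. For the measured compounds named here, it offers no size to carry over, and no measured pair alters the ester. With no readable step to draw on, no step beyond the usual scatter is expected in this assay, in either direction. The expected result is a number no higher from compound 1 to compound 4 (the limit leaves the size open). Most likely the assay will again report only a limit. For compound 4 the estimate is 100000 nM, with an expected range of 50000 nM to 200000 nM.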

Compound 4, half-maximal inhibitory concentration: > 100000 nM
Compound 4 ended at the assay's limit (the forecaster's own chance of this, stated with the estimate: 85%); the middle value lies on the limit itself.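

Compound 1 and compound 4 are both recorded in this assay only as limits, and no step can be read between them for the change from ethoxycarbonyl to methoxycarbonyl. The whole set rests on one entry: the limit of > 100000 nM in this assay, at which 4 of the 4 values shown sit. The compounds shown leave open what exact value any of them would have, and which change, if any, would bring a compound within the measurable range.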